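This account rests on a few compounds, and the source may have more. Where it says the series, first, only, none or still open, it means among the compounds named here.

The measured compounds and their values in an ADME assay on Caco-2 cells (Homo sapiens) for permeability, in the apical to basolateral direction (on this read-out higher numbers stand for higher permeability and lower numbers for lower permeability), are:
compound 1 `CCC(=O)N1CCC(CN(C2Cc3cc(C#N)ccc3N(Cc3cncn3C)C2)S(=O)(=O)c2ccccn2)CC1`, 0.5 10^-6 cm/s;
compound 2 `CCCC(=O)N1CCC(CN(C2Cc3cc(C#N)ccc3N(Cc3cncn3C)C2)S(=O)(=O)c2ccccn2)CC1`, 0.5 10^-6 cm/s;
compound 3 `CC(C)OC(=O)N1CCC(CN(C2Cc3cc(C#N)ccc3N(Cc3cncn3C)C2)S(=O)(=O)c2ccccn2)CC1`, 1 10^-6 cm/s.

Compound 2 stands level with compound 1 at the digits given, and the two together are the lowest of the three numbers. Its nearest neighbour is compound 1, with no change at the digits printed from compound 1 to compound 2 (within the scatter). Its furthest is compound 3, with a 2.0-fold higher number from compound 2 to compound 3 (0.30 log units; within the scatter). The step from compound 1 to compound 3 reads the same way, a 2.0-fold higher number from compound 1 to compound 3 (0.30 log units; within the scatter).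

Compound 4 `CC(C)NC(=O)N1CCC(CN(C2Cc3cc(C#N)ccc3N(Cc3cncn3C)C2)S(=O)(=O)c2ccccn2)CC1` has not yet been measured in this assay. It differs from compound 2 in one place: isopropylamino in place of propyl on a carbonyl carbon. The measured steps that bear on this are the two that exchange the group on the carbonyl carbon, a 2.0-fold higher number from compound 2 to compound 3 (0.30 log units; within the scatter) and a 2.0-fold higher number from compound 1 to compound 3 (0.30 log units; within the scatter), both of which stayed within the scatter. Going by the values given here, none of the measured compounds carries an isopropylamino group, or any hydrogen-bond donor, on that carbonyl carbon, so that part of the change has no direct guide among the numbers so far. On this basis compound 4 is expected to sit close to compound 2, and no change at the digits printed from compound 2 to compound 4 (within the scatter) is expected to remain within the scatter. The estimate for compound 4 is 0.5 10^-6 cm/s, with a range from 0.25 10^-6 cm/s to 1 10^-6 cm/s.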

Compound 4, apparent permeability: 0.6 10^-6 cm/s
Compound 4: middle estimate off by 1.2-fold (0.08 log units), on the low side, and the stated range covers the measured number.
By their numbers in this assay, from the lowest: compounds 1, 2, 4 and 3 (each within the scatter of the next).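

In this assay, going by these compounds alone, the exchange on the carbonyl carbon now includes a group with a hydrogen-bond donor, which none of the earlier compounds carried there, and replacing propyl with isopropylamino gives a 1.2-fold higher number from compound 2 to compound 4 (0.08 log units; within the scatter) and replacing ethyl with isopropylamino gives a 1.2-fold higher number from compound 1 to compound 4 (0.08 log units; within the scatter). Replacing isopropoxy with isopropylamino gives a 1.7-fold lower number from compound 3 to compound 4 (0.22 log units; within the scatter), so the nitrogen-linked group joins the carbon-linked and oxygen-linked groups, and all four compounds remain within the scatter of one another at this position on the shared core. The data shown offer no independent measurement that could explain this lack of separation.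

The compounds shown leave open whether a carboxylic acid, a primary amine, a morpholine ring or a much longer chain on this carbonyl carbon would move the number beyond the scatter. They also leave open whether isopropylamino and isopropoxy would remain this close if another part of the shared core were changed, since all four compounds carry the same remainder of the structure.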